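A few compounds are considered here, and "the series" means these few. Any claim that something is new, unique, unknown or untested is made for them only; others in the source may bear on it.

Compound 1 `CN(C)c1ncnc2c1c(-c1ccoc1)cn2[C@@H]1O[C@H](CO)[C@@H](O)[C@H]1O` gives the higher of the two numbers seen so far in a functional assay on CCRF-CEM cells (Homo sapiens), read by MTT assay, with a stated time of 72 h (on this read-out higher numbers stand for weaker inhibition and lower numbers for stronger inhibition), with compound 1 at 13300 nM. Among the compounds with values here, compound 2 `C#Cc1cn([C@@H]2O[C@H](CO)[C@@H](O)[C@H]2O)c2ncnc(N(C)C)c12` is the other measured compound, and in this assay compound 2 gives 90 nM; the only measured step, a 150-fold lower number from compound 1 to compound 2 (2.17 log units; beyond the scatter), changes a different part of the core. Within the data shown here, compound 3 `CNc1ncnc2c1c(-c1ccoc1)cn2[C@@H]1O[C@H](CO)[C@@H](O)[C@H]1O` differs from compound 1 by hydrogen in place of methyl on a nitrogen on an aromatic ring, a change that no measured step bears on. Without a guide, the expected step of a 1.5-fold lower number from compound 1 to compound 3 (0.17 log units; within the scatter) is none beyond the scatter. Compound 3 is therefore estimated at 9000 nM, within 2500 nM to 30000 nM.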

Compound 3, half-maximal inhibitory concentration: > 20000 nM
Compound 3 ended at the assay's limit (the forecaster's own chance of this, stated with the estimate: 5%); middle value at least 2.2-fold (0.34 log units) from the limit.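

Within the data shown here, the change from dimethylamino to methylamino is the first measured change on this nitrogen, and in this assay compound 3 gives a limit of the assay, not a number: the limit of > 20000 nM in this assay, at which 1 of the 3 values shown sits. On these data alone, the step is therefore only a floor, an at least 1.5-fold higher number from compound 1 to compound 3 (0.17 log units; that floor lies within the scatter), so taking away this methyl brings no gain in inhibition, while the true size of any loss stays unknown.

Still open, as far as these compounds go, is how an unsubstituted amino group or a longer chain such as ethyl would behave on this nitrogen. Also open, from the compounds shown here alone, is whether the same change would read differently with the ethynyl group of compound 2 in place of furan-3-yl.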